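A Methyl for a Nitro on the Benzyl Arm

This account rests on a few compounds, and the source may have more. Where it says the series, first, only, none or still open, it means among the compounds named here.

Three compounds have been measured in a functional assay on HeLa cells (Homo sapiens) for antiproliferative activity, read by MTT assay, with a stated time of 24 h; a higher number here means a weaker inhibitor, a lower number a stronger inhibitor:
compound 1, `c1ccc(CSc2nnc(-c3ccc4c(c3)OCCO4)n2-c2ccccc2)cc1`: 32800 nM
compound 2, `O=[N+]([O-])c1ccccc1CSc1nnc(-c2ccc3c(c2)OCCO3)n1-c1ccccc1`: 69800 nM
compound 3, `O=[N+]([O-])c1cccc(CSc2nnc(-c3ccc4c(c3)OCCO4)n2-c2ccccc2)c1`: 45200 nM

Compound 3 holds the second highest of the three numbers. Its nearest neighbour is compound 1, and the step of a 1.4-fold higher number from compound 1 to compound 3 (0.14 log units; within the scatter) stays within the scatter; the step of a 1.5-fold lower number from compound 2 to compound 3 (0.19 log units; within the scatter) also stays within the scatter. Among the compounds with values here, the only step that reaches beyond the scatter is a 2.1-fold higher number from compound 1 to compound 2 (0.33 log units; beyond the scatter), a modest one.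

Compound 4, `Cc1ccc(CSc2nnc(-c3ccc4c(c3)OCCO4)n2-c2ccccc2)cc1`, differs from compound 3 in one place: 4-methylphenyl in place of 3-nitrophenyl on a saturated chain carbon bound to a sulfur. Within the data shown here, no measured step carries a methyl group, so the change is only loosely anchored. What the series does show is that the benzyl arm tolerates a nitro group with little movement: one placement gave a modest rise, the other none beyond the scatter. Removing that group and adding a methyl is therefore expected to leave compound 4 close to compounds 1 and 3, with no step beyond the scatter anticipated. The expected step is a 1.3-fold lower number from compound 3 to compound 4 (0.11 log units; within the scatter). For compound 4 the estimate in this assay is 35000 nM, with a range from 15000 nM to 80000 nM.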

Compound 4, half-maximal inhibitory concentration: 49700 nM
Beside the measured number, compound 4's estimate is 1.4-fold (0.15 log units) below it, within the range that was stated.
By their numbers in this assay, from the lowest: compounds 1, 3, 4 and 2 (each within the scatter of the next, the first and the last beyond it).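

In this assay, within the data shown here, a methyl group added to the benzyl arm gives a 1.5-fold higher number from compound 1 to compound 4 (0.18 log units; within the scatter), the first reading of a group other than nitro at this place, and the exchange of 3-nitrophenyl for 4-methylphenyl on a saturated chain carbon bound to a sulfur gives a 1.1-fold higher number from compound 3 to compound 4 (0.04 log units; within the scatter). Among these compounds, with a 1.4-fold lower number from compound 2 to compound 4 (0.15 log units; within the scatter) as well, compound 4 stands within the scatter of each of the other three compounds, so a carbon-only 4-methylphenyl with no hydrogen-bond acceptors reads the same here as a 3-nitrophenyl with its oxygen and nitrogen atoms, and the gap between compound 1 and compound 2 remains the only step beyond the scatter. Nothing available explains why these numbers stay so close together.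

The four compounds leave open whether an amine or a carboxylic acid on the phenyl ring of the benzyl arm, or a longer chain such as propyl in place of the methyl, would move the number beyond the scatter. They also leave open whether any change at this place could bring the number well below that of compound 1, since every group shown so far gives a number that is no lower.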